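The source may hold more compounds than are shown below. What is called first, only, known or untested is meant among the compounds shown, and "the series" means these compounds.

Measured so far in a physicochemical assay for lipophilicity; on this read-out higher numbers stand for higher lipophilicity and lower numbers for lower lipophilicity:
compound 1 `CCCCN(C)/N=N/c1ccc(C(=O)O)cc1` gives 0.97
compound 2 `CCCCCCCCN(C)/N=N/c1ccc(C(=O)O)cc1` gives 2.77
compound 3 `CCCCN(C)/N=N/c1ccc(C(N)=O)cc1` gives 2.46

Compound 2 differs from compound 1 by butyl in place of hydrogen on a saturated chain carbon, four bonds along the chain from an amine nitrogen; this change made a number 1.80 log units higher from compound 1 to compound 2 (beyond the scatter). The core of compound 3 differs from that of compound 1 by amino in place of hydroxy on a carbonyl carbon, which made a number 1.49 log units higher from compound 1 to compound 3 (beyond the scatter). Compound 4 `CCCCCCCCN(C)/N=N/c1ccc(C(N)=O)cc1` is not yet measured in this assay. Among the compounds with values here, it differs from compound 3 by butyl in place of hydrogen on a saturated chain carbon, four bonds along the chain from an amine nitrogen, the same change at the same place as the one between compound 1 and compound 2, now carried out on the core of compound 3. Within the data shown here, a step of similar size is expected, resting on a number 1.80 log units higher from compound 1 to compound 2 (beyond the scatter), with no second example of this change on the core of compound 3 to check it against. Compound 4 is therefore expected to show a number 1.79 log units higher from compound 3 to compound 4 (beyond the scatter). Compound 4 is estimated at 4.25, between 3.85 and 4.65.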

Compound 4, partition coefficient: 4.7
For compound 4 the middle estimate is 0.45 log units below the measured one; measured number outside the range, above it.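

In this assay, butyl in place of hydrogen gives a number 2.24 log units higher from compound 3 to compound 4 (beyond the scatter) on the core of compound 3, in the same direction as a number 1.80 log units higher from compound 1 to compound 2 (beyond the scatter) on the core of compound 1, while amino in place of hydroxy gives a number 1.93 log units higher from compound 2 to compound 4 (beyond the scatter), in the same direction as a number 1.49 log units higher from compound 1 to compound 3 (beyond the scatter). The direction of the butyl change therefore carries between these two cores, but with one pair per core this does not establish a fixed step size or show that the change would carry to any other core. Nothing available explains the size of either step.

Open, going by these compounds, is whether the butyl step keeps its direction on a core carrying a nitrile or an ester instead of the amide. Also open, on these data alone, is how the series behaves with a longer chain than that of compound 4.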